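Series notes: compound 1 to compound 3

The compounds below may be only part of what the source reports. "The series", "measured", "known", "first", "only" and "open" are said of these compounds alone.

Compound 1 `COC(=O)CCNC(=O)[C@@H]1O[P@@](=O)(OCOC(=O)c2ccnn2C)OCC1(C)C` has been measured in an ADME assay on blood (Homo sapiens) for pharmacokinetics; on this read-out lower numbers stand for a shorter-lived compound and higher numbers for a longer-lived compound. In this assay compound 1 gives > 1 h, which is a limit of the assay rather than a number. Compound 1 therefore stands at the limit of > 1 h in this assay, at which 1 of the 2 values shown sits. Compound 2 `CC(C)(C)C(=O)OCO[P@@]1(=O)OCC(C)(C)[C@H](C(=O)NCCC(=O)OCCS(C)(=O)=O)O1` gives < 0.16 h in this assay, likewise a limit. Compound 2 stands at the limit of < 0.16 h in this assay, at which 1 of the 2 values shown sits. Among the compounds with values here, no step between measured compounds is available. Compound 3 `COC(=O)CCNC(=O)[C@@H]1O[P@@](=O)(OCOC(=O)c2ocnc2C)OCC1(C)C` carries 4-methyl-1,3-oxazol-5-yl in place of 1-methyl-1H-pyrazol-5-yl on a carbonyl carbon. Within the data shown here, no measured step speaks to this change, so the expected shift stays within the usual scatter, a step that the limit leaves unreadable from compound 1 to compound 3. Compound 3 is estimated at 1.5 h, between 0.5 h and 4 h.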

Compound 3, half-life: 0.52 h
The estimate for compound 3 lay 2.9-fold (0.46 log units) above the measured number, and the stated range covers the measured number.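

The exchange of 1-methyl-1H-pyrazol-5-yl for 4-methyl-1,3-oxazol-5-yl on a carbonyl carbon gives the first step readable at this position in this assay: an at least 1.9-fold lower number from compound 1 to compound 3 (0.28 log units; that floor lies within the scatter). With this change, compound 3 gives a number rather than a limit, 0.52 h. Compound 1 remains a limit of the assay: the limit of > 1 h in this assay, at which 1 of the 3 values shown sits.

Going by these compounds, the full size of the step therefore stays open, and its floor alone does not establish a real difference. Also open, on these data alone, is how a phenyl ring or a pyridine ring on the same carbonyl carbon would read.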